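Ether-linked aryl swap on the pyridazinone amide series

The source may report more compounds than this note shows. Statements on the series, on what has been measured and on what is new or still open speak of the compounds shown alone.

Measured compounds in a functional assay on MCF7 cells (Homo sapiens) for cytotoxicity, read by MTT assay, with a stated time of 72 h; on this read-out higher numbers stand for weaker inhibition and lower numbers for stronger inhibition:
compound 1 `CNC(=O)c1cc(Oc2ccc(NC(=O)c3nn(-c4ccccc4C(F)(F)F)c(=O)cc3C)cc2F)ccn1`, 35700 nM
compound 2 `CNC(=O)c1cc(Oc2ccc(NC(=O)c3nn(-c4ccc(Br)cc4F)c(=O)cc3C)cc2F)ccn1`, 9360 nM
compound 3 `CNC(=O)c1cc(Oc2ccc(NC(=O)c3nn(-c4cccc(F)c4)c(=O)cc3C)cc2F)ccn1`, 6410 nM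

Compound 1 gives the highest number of the three. Its step to compound 2 is a 3.8-fold lower number from compound 1 to compound 2 (0.58 log units; beyond the scatter), and its step to compound 3 is a 5.6-fold lower number from compound 1 to compound 3 (0.75 log units; beyond the scatter); both steps change only the aryl group on the aromatic nitrogen. Between compound 2 and compound 3 the step is a 1.5-fold lower number from compound 2 to compound 3 (0.16 log units; within the scatter).

Compound 4 `Cc1cc(=O)n(-c2ccccc2C(F)(F)F)nc1C(=O)Nc1ccc(Oc2ncnc3ccsc23)c(F)c1` differs from compound 1 at a different place: a group of 9 heavy atoms (6 carbon, 2 nitrogen, 1 sulfur; one five-membered aromatic ring with 1 hetero atom, one six-membered aromatic ring with 2 hetero atoms) in place of a group of 10 heavy atoms (7 carbon, 2 nitrogen, 1 oxygen; one six-membered aromatic ring with 1 hetero atom), on an oxygen on an aromatic ring. The aryl group on the aromatic nitrogen is kept as in compound 1.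

For the measured compounds named here, none of the measured steps touches the group on the ether oxygen, so no step bears directly on this change; the measured steps only show that the series moves by modest amounts when an aryl group is exchanged. For compound 4 the expected step is therefore a 1.2-fold lower number from compound 1 to compound 4 (0.08 log units; within the scatter), with no direction claimed beyond the scatter and a wide range. The estimate for compound 4 in this assay is 30000 nM, between 5000 nM and 150000 nM.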

Compound 4, half-maximal inhibitory concentration: 6020 nM
Compound 4: the middle estimate sits 5.0-fold (0.70 log units) above what was measured, and the stated range covers the measured number.
By their numbers in this assay, from the lowest: compounds 4, 3 and 2 (each within the scatter of the next); then compound 1.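

The group on the ether oxygen also moves the number in this assay: replacing 2-(methylcarbamoyl)pyridin-4-yl with the sulfur-containing group gives a 5.9-fold lower number from compound 1 to compound 4 (0.77 log units; beyond the scatter) with 2-(trifluoromethyl)phenyl kept on the aromatic nitrogen. In this one pair, the 2-(methylcarbamoyl)pyridin-4-yl group and its hydrogen-bond donor are therefore not needed to reach the lower number, since the entering group has no such donor. No available measurement accounts for this step.

On these data alone, it remains open whether the same exchange gives a similar step with 4-bromo-2-fluorophenyl or 3-fluorophenyl on the aromatic nitrogen. Also open, as far as these compounds go, is how simpler groups on the ether oxygen, such as an unsubstituted phenyl or pyridin-4-yl, or a pyridine carrying a carboxylic acid in place of the methylcarbamoyl, would read in this assay and compare with compound 1.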